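The source may report more compounds than this note shows. Statements on the series, on what has been measured and on what is new or still open speak of the compounds shown alone.

The series is read against compound 1 `CCCCCCCC/C=C\CCCCCCCCOC[C@@H]1CCCN1`, which in a functional assay on PANC-1 cells (Homo sapiens) for inhibition, read by XTT assay, with a stated time of 72 h (a lower number here means a stronger inhibitor, a higher number a weaker inhibitor), gives 4700 nM. Compound 2 `CCCCCCCC/C=C\CCCCCCCCOC[C@@H]1CCCN1[S+]([O-])c1ccc(C)cc1` reads > 100000 nM, a limit of the assay and not a number. Compound 3 `CCCCCCCC/C=C\CCCCCCCCOC[C@@H]1CCCN1C(=O)[C@@H]1CCCN1C(=O)OC(C)(C)C` reads > 100000 nM, also only a limit. This is the limit of > 100000 nM in this assay, at which 2 of the 3 values shown sit.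

Compound 4 `CCCCCCCC/C=C\CCCCCCCCOC[C@@H]1CCCN1C(=O)CN` has not yet been measured. Its difference from compound 3 is aminomethyl in place of 1-(tert-butoxycarbonyl)pyrrolidin-2-yl on a carbonyl carbon, with the amide-type nitrogen in a ring retained.

Going by the values given here, only one measured step bears on this change: an at least 21-fold higher number from compound 1 to compound 2 (1.32 log units; beyond the scatter). That step was large, and it put a new group on the amine nitrogen in a ring. Compound 4 still carries a group on that nitrogen, so that step argues against assuming a full return to the value of compound 1, 4700 nM. However, the entering group has far fewer heavy atoms than the leaving one, so some recovery from the limit is expected.

Expected in this assay is an at least 6.6-fold lower number from compound 3 to compound 4 (0.82 log units; beyond the scatter), a sizeable move towards a lower number, with a real chance of no number at all. Compound 4 is estimated at 15000 nM, with an expected range of 3000 nM to 80000 nM.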

Compound 4, half-maximal inhibitory concentration: 7700 nM
Compound 4: the middle estimate sits 1.9-fold (0.29 log units) above what was measured, and the stated range covers the measured number.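

In this assay, a group on the amine nitrogen in a ring is compatible with activity: with (aminomethyl)carbonyl in place of hydrogen, the result is a 1.6-fold higher number from compound 1 to compound 4 (0.21 log units; within the scatter), so compound 4 keeps the level of compound 1. The loss seen earlier therefore does not apply to every group on that nitrogen, as shown by an at least 12-fold lower number from compound 2 to compound 4 (1.11 log units; beyond the scatter) and, with aminomethyl in place of 1-(tert-butoxycarbonyl)pyrrolidin-2-yl on a carbonyl carbon, by an at least 12-fold lower number from compound 3 to compound 4 (1.11 log units; beyond the scatter). The readings for compound 2 and compound 3 are limits and not numbers, so these two steps give only minimum sizes: the limit of > 100000 nM in this assay, at which 2 of the 4 values shown sit.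

The step from compound 3 to compound 4 removes the ring, the tert-butoxycarbonyl group and the stereocentre and adds the primary amine all at once, so the compounds shown cannot assign the change to any one of these features. From the compounds shown here alone, it remains open whether a free pyrrolidin-2-yl group or a plain methyl group on the same carbonyl carbon would read like compound 4, and whether a shorter chain in place of the long alkenyl chain would keep this level.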